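The compounds below may be only part of what the source reports. "The series", "measured", "known", "first", "only" and "open" are said of these compounds alone.

In a functional assay on PC-3 cells (Homo sapiens) for antiproliferative activity, read by MTT assay, with a stated time of 48 h (a lower number here means a stronger inhibitor, a higher number a weaker inhibitor), compound 3 `O=C(NO)c1ccc(/C=C/c2ccccc2O)o1` gives 91300 nM, the highest number of the three measured compounds and beyond the scatter of both others. Compound 1 `O=C(/C=C/c1ccc(/C=C/C(=O)c2cccc(Cl)c2)o1)NO` gives 9600 nM and compound 2 `O=C(/C=C/c1ccc(/C=C/C(=O)c2ccccc2)o1)NO` gives 13300 nM. Compound 4 `COc1cccc(/C=C/c2ccc(C(=O)NO)o2)c1O` differs from compound 3 by methoxy in place of hydrogen on an aromatic carbon, ortho to a hydroxy group. Among the compounds with values here, the only measured substituent step is a 1.4-fold higher number from compound 1 to compound 2 (0.14 log units; within the scatter), on a core other than that of compound 3. That step is a weak guide, but it offers no ground for a large change, so no step beyond the scatter is expected in this assay. The expected step is a 1.3-fold lower number from compound 3 to compound 4 (0.12 log units; within the scatter). For compound 4 the estimated value is 70000 nM, with an expected range of 25000 nM to 200000 nM.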

Compound 4, half-maximal inhibitory concentration: 35100 nM
Compound 4: middle estimate off by 2.0-fold (0.30 log units), on the high side, and the stated range covers the measured number.
By their numbers in this assay, from the lowest: compounds 1 and 2 (each within the scatter of the next); then compound 4; then compound 3.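

Methoxy in place of hydrogen on an aromatic carbon, ortho to a hydroxy group, gives a 2.6-fold lower number from compound 3 to compound 4 (0.42 log units; beyond the scatter) in this assay. Within the data shown here, this is the first substituent step to lie beyond the scatter, whereas the only earlier one (a 1.4-fold higher number from compound 1 to compound 2 (0.14 log units; within the scatter)), on a different core and at a different place, stayed within it. Nothing measured here accounts for the change.

From the compounds shown here alone, whether ethoxy or an amine on this carbon gives a step of similar size remains open. So does whether the methoxy step carries over to the core of compound 1.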